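A chloro group on the anilino of compound 1

The source may report more compounds than this note shows. Statements on the series, on what has been measured and on what is new or still open speak of the compounds shown alone.

In a functional assay on CCRF-CEM cells (Homo sapiens) for antiproliferative activity, read by cell counting, with a stated time of 2 days (a lower number here means a stronger inhibitor, a higher number a weaker inhibitor), compound 1 `COc1cc(C(=O)c2sc(Nc3ccccc3)nc2N)cc(OC)c1OC` reads 9.4 nM and compound 3 `COc1ccc(Nc2nc(N)c(C(=O)c3ccc(OC)c(OC)c3)s2)cc1` reads 10 nM in the same range, within the scatter of each other. Compound 2 `COc1ccc(C(=O)c2sc(Nc3ccccc3)nc2N)cc1OC` reads 6900 nM and stands far off on the weak side. Compound 4 `COc1cc(C(=O)c2sc(Nc3ccc(Cl)cc3)nc2N)cc(OC)c1OC` keeps the core of compound 1 but carries chloro in place of hydrogen on an aromatic carbon, para to a large group, turning phenyl into 4-chlorophenyl: chloro in place of hydrogen on an aromatic carbon counts the change.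

The nearest evidence is a 690-fold lower number from compound 2 to compound 3 (2.84 log units; beyond the scatter) with methoxy in place of hydrogen on an aromatic carbon of the anilino. That step is large, but it starts from a weak compound and involves methoxy, not chloro. The step of a 730-fold higher number from compound 1 to compound 2 (2.87 log units; beyond the scatter) is equally large but changes another part of the structure. Compound 1 already sits low, so no large gain is expected. The expected change is modest, a 2.7-fold higher number from compound 1 to compound 4 (0.42 log units; beyond the scatter) as estimated here. For compound 4 the estimate is 25 nM within an expected range of 6 nM to 100 nM in this measurement.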

Compound 4, half-maximal inhibitory concentration: 190 nM
For compound 4 the middle estimate is 7.6-fold (0.88 log units) below the measured one; the measured number lies above the stated range.
By their numbers in this assay, from the lowest: compounds 1 and 3 (each within the scatter of the next); then compound 4; then compound 2.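

In this assay, chloro in place of hydrogen on the anilino of compound 1, para to a large group, gives a 20-fold higher number from compound 1 to compound 4 (1.31 log units; beyond the scatter), so this place on the core of compound 1 is not indifferent to a single added atom. Going by these compounds alone, the only earlier change on the anilino was a 690-fold lower number from compound 2 to compound 3 (2.84 log units; beyond the scatter), with methoxy on a different core, and it ran in the opposite direction. Nothing given here accounts for the rise.

The compounds shown leave open how a methyl, a fluoro or an amine at this place on the core of compound 1 would read, and so whether the rise belongs to chloro alone or to any group there. They also leave open what chloro would do on the core of compound 2.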